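The source may report more compounds than this note shows. Statements on the series, on what has been measured and on what is new or still open speak of the compounds shown alone.

Working notes on the series. Compound 1 `COc1ncc(-c2ccc3nc(NC(=O)NC4CC4)sc3c2)cc1NS(=O)(=O)c1ccc(F)cc1` gives 470 nM in a functional assay on HCT-116 cells (Homo sapiens) for antiproliferative activity, read by MTT assay, with a stated time of 72 h; on this read-out lower numbers stand for stronger inhibition and higher numbers for weaker inhibition. Compound 2 `COc1ncc(-c2ccc3nc(NC(=O)NCCN4CCCCC4)sc3c2)cc1NS(=O)(=O)c1ccc(F)cc1` gives 610 nM; the step of a 1.3-fold higher number from compound 1 to compound 2 (0.11 log units; within the scatter) stays within the scatter. Compound 3 `CCCNc1nc2ccc(-c3cnc(Cl)c(NS(=O)(=O)c4ccc(F)cc4)c3)cc2s1` yields only a limit and not a number, > 20000 nM (the limit of > 20000 nM in this assay, at which 1 of the 3 values shown sits). Compound 4 `O=C(Nc1nc2ccc(-c3cnc(Cl)c(NS(=O)(=O)c4ccc(F)cc4)c3)cc2s1)NC1CC1` is not yet measured; it differs from compound 3 by cyclopropylcarbamoyl in place of propyl on a nitrogen on an aromatic ring. Within the data shown here, no measured step covers this change: the only measured step, a 1.3-fold higher number from compound 1 to compound 2 (0.11 log units; within the scatter), sits on an amide-type nitrogen and sets no size here. Compound 1 carries the same cyclopropylcarbamoyl group on its own core and gives 470 nM. Compound 3, with propyl, shows only a limit. Compound 4 is therefore expected at 1500 nM, range 400 nM to 8000 nM, the expected step being an at least 13-fold lower number from compound 3 to compound 4 (1.12 log units; beyond the scatter).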

Compound 4, half-maximal inhibitory concentration: 1750 nM
Beside the measured number, compound 4's estimate is 1.2-fold (0.07 log units) below it; measured number inside the range.
By their numbers in this assay, from the lowest: compounds 1 and 2 (each within the scatter of the next); then compound 4. At a limit, above all of these: compound 3.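

Among these compounds, on a nitrogen on an aromatic ring, cyclopropylcarbamoyl in place of propyl gives an at least 11-fold lower number from compound 3 to compound 4 (1.05 log units; beyond the scatter), so this position responds to the change in a way the earlier compounds could not show. Compound 3 is only a limit and not a number: the limit of > 20000 nM in this assay, at which 1 of the 4 values shown sits. With cyclopropylcarbamoyl held constant, chloro in place of methoxy on an aromatic carbon gives a 3.7-fold higher number from compound 1 to compound 4 (0.57 log units; beyond the scatter), a smaller step than the one at the nitrogen.

As far as these compounds go, whether propyl on the core of compound 1 would also lose activity remains open. So does the effect of a longer chain or a carboxylic acid in place of cyclopropyl with chloro present.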